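Removing a methyl from an aryl ether: a weakly active pair

A few compounds are considered here, and "the series" means these few. Any claim that something is new, unique, unknown or untested is made for them only; others in the source may bear on it.

Within the data shown here, compound 2 `COc1cc(-c2nn(-c3cccc(NC(=O)Nc4ccc(Cl)c(C(F)(F)F)c4)c3)cc2-c2ccncc2)ccc1Cl` is the only compound here with a numeric result. In a functional assay on HOP-62 cells (Homo sapiens) for inhibition, read by sulforhodamine B assay, with a stated time of 48 h (a lower number here means that less compound is tolerated, a higher number that more compound is tolerated), compound 2 gives 31000 nM. Compound 1 `O=C(Nc1cccc(-n2cc(-c3ccncc3)c(-c3ccc(Cl)c(O)c3)n2)c1)Nc1ccc(Cl)c(Cl)c1` reaches only a limit of the assay, and in this assay compound 1 gives > 32500 nM; this is the limit of > 32500 nM in this assay, at which 1 of the 2 values shown sits. Compound 3 `O=C(Nc1cccc(-n2cc(-c3ccncc3)c(-c3ccc(Cl)c(O)c3)n2)c1)Nc1ccc(Cl)c(C(F)(F)F)c1` differs from compound 2 by hydrogen in place of methyl on an oxygen on an aromatic ring. With nothing comparable measured, the step from compound 2 to compound 3 is expected to stay within the scatter, as a 1.0-fold higher number from compound 2 to compound 3 (0.01 log units; within the scatter). Compound 3 is thus expected to show about 32000 nM, between 16000 nM and 65000 nM, with a fair chance of only a limit.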

Compound 3, concentration lethal to 50% of the cells: > 32500 nM
Compound 3: a limit, no number; the forecaster's own chance of this, stated with the estimate: 50%; at least 1.0-fold (0.00 log units) between middle value and limit.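

In this assay compound 3 gives > 32500 nM, which is a limit of the assay and not a number. Going from methoxy to hydroxy gives an at least 1.0-fold higher number from compound 2 to compound 3 (0.02 log units; that floor lies within the scatter), so this change at the oxygen shows only a floor for the step, not its true size. The series now gathers at one limit: the limit of > 32500 nM in this assay, at which 2 of the 3 values shown sit.

On these data alone, the step between the two compounds at the limit, trifluoromethyl in place of chloro, cannot be read, and the true distance between methoxy and hydroxy stays open. Also open, as far as these compounds go, is how an amine or a longer ether chain in this place would behave in this assay.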